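This account rests on a few compounds, and the source may have more. Where it says the series, first, only, none or still open, it means among the compounds named here.

Compound 1 `COc1cc2nc(/C=C/c3ccccn3)nc(N3CCC(CCNS(N)(=O)=O)CC3)c2cc1OC` is measured in an assay on cells for inhibition of Ectonucleotide pyrophosphatase/phosphodiesterase family member 1 (Homo sapiens), with a stated time of 60 min, tested at 1 uM (a higher number here means more inhibition at the concentration tested (going by the name of the read-out), a lower number less inhibition), where compound 1 gives 85%. Among the three compounds measured, compound 1 stands second highest; its nearest neighbour is compound 3 `COc1cccc(/C=C/c2nc(N3CCC(CCNS(N)(=O)=O)CC3)c3cc(OC)c(OC)cc3n2)c1`, which in this assay gives 88%, a difference that lies within the scatter, while the furthest is compound 2 `COc1cc2nc(/C=C/c3cccc(F)c3)nc(N3CCC(CCNS(N)(=O)=O)CC3)c2cc1OC`, which gives 14%.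

Compound 4 `COc1cc2nc(CCc3ccc(F)cc3)nc(N3CCC(CCNS(N)(=O)=O)CC3)c2cc1OC` differs from compound 1 in one place: 2-(4-fluorophenyl)ethyl in place of 2-(pyridin-2-yl)ethenyl on an aromatic carbon. For the measured compounds named here, two measured steps bear on this change. The first is a number 71 percentage points lower from compound 1 to compound 2 (beyond the scatter), a large loss when a fluorophenyl group replaced the pyridin-2-yl group on the same chain carbon. The second is a number 74 percentage points higher from compound 2 to compound 3 (beyond the scatter), showing that the fluoro-bearing phenyl sits far beneath the methoxy-bearing one. Going by the values given here, no measured step speaks to the loss of the double bond outside aromatic rings, so that part of the change carries no evidence either way.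

Since compound 4 carries a fluorophenyl group where compound 1 carried pyridin-2-yl, a large drop is expected, of about a number 65 percentage points lower from compound 1 to compound 4 (beyond the scatter). Compound 4 is therefore estimated to give 20% in this assay, with a range from 4% to 55%.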

Compound 4, a percentage reported as inhibition, at one concentration (the size of the read-out at that concentration, not a potency): 69%
Beside the measured number, compound 4's estimate is 49 percentage points below it; measured number outside the range, above it.
By their numbers in this assay, from the lowest: compound 2; then compound 4; then compounds 1 and 3 (each within the scatter of the next).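

In this assay, the change to 2-(4-fluorophenyl)ethyl from 2-(3-fluorophenyl)ethenyl gives a number 55 percentage points higher from compound 2 to compound 4 (beyond the scatter), so a fluorine-bearing phenyl ring at this position does not in itself bring the near-complete loss seen earlier. Replacing 2-(pyridin-2-yl)ethenyl gives a number 16 percentage points lower from compound 1 to compound 4 (beyond the scatter) and replacing 2-(3-methoxyphenyl)ethenyl gives a number 19 percentage points lower from compound 3 to compound 4 (beyond the scatter), so a group without a double bond outside aromatic rings keeps much of the inhibition at this position, although both of these modest steps lie beyond the scatter. No measurement here explains why this group fares so much better than the 2-(3-fluorophenyl)ethenyl group.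

The large step combines two changes, the place of the fluorine on the ring and the saturation of the chain, and the compounds shown cannot separate them; a 2-(4-fluorophenyl)ethenyl or a 2-(3-fluorophenyl)ethyl group would tell the two apart. Going by these compounds, it also remains open how this position would respond to a longer chain between the core and the ring, or to an amine or a carboxylic acid on that ring.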